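Carboxy on the pyridine ring of compound 1

This account rests on a few compounds, and the source may have more. Where it says the series, first, only, none or still open, it means among the compounds named here.

Measured so far in an assay on isolated protein for activation of cGMP-dependent protein kinase 1 (Homo sapiens), read by ADP-Glo, with stated times of 120 min and 40 min; a lower number here means that less compound is needed, a higher number that more compound is needed for the effect:
compound 1 `Clc1cc(Cl)cc(CO[C@H]2CCCN(Cc3cccnc3)[C@H]2c2ccccc2)c1` gives 112000 nM
compound 2 `COC(=O)Nn1c(C[C@H]2CCC[C@H](OCc3cc(C(F)(F)F)cc(C(F)(F)F)c3)[C@@H]2c2ccccc2)n[nH]c1=O` gives 4500 nM

Compound 1 has the highest of the two numbers; compound 2 sits at a lower number, a gap beyond the scatter, though the two share no single-point difference and their values are all that can be compared.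

Compound 3 `O=C(O)c1cncc(CN2CCC[C@H](OCc3cc(Cl)cc(Cl)c3)[C@@H]2c2ccccc2)c1` is not yet measured. It differs from compound 1 by carboxy in place of hydrogen on an aromatic carbon, on the aromatic carbon two atoms from the ring nitrogen, meta to a large group. Among the measured compounds shown here, no step of this kind is known in this set, so the expected step is uncertain; a modest move toward a lower number is estimated, a 1.9-fold lower number from compound 1 to compound 3 (0.27 log units; within the scatter). Compound 3 is therefore expected at 60000 nM, range 15000 nM to 250000 nM.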

Compound 3, half-maximal effective concentration: 117000 nM
Beside the measured number, compound 3's estimate is 2.0-fold (0.29 log units) below it; low and high end bracket the measured number.
By their numbers in this assay, from the lowest: compound 2; then compounds 1 and 3 (each within the scatter of the next).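

In this assay, carboxy in place of hydrogen on the aromatic carbon two atoms from the ring nitrogen, meta to a large group, gives a 1.0-fold higher number from compound 1 to compound 3 (0.02 log units; within the scatter) on the core of compound 1. Among the compounds shown here, this is the first single-point step, and it shows that this position accepts carboxy with no change beyond the scatter. No supporting measurement bears on this result. From the compounds shown here alone, whether an amine or a methyl ester on the same carbon reads alike remains open, as does carboxy on another carbon of this ring.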